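The compounds below may be only part of what the source reports. "The series", "measured", "known", "first", "only" and "open" are said of these compounds alone.

Measured compounds:
- compound 1 `Oc1cccc2cc(-c3ccccc3)ccc12`: 20%
- compound 2 `Oc1cccc(-c2ccc3c(O)cccc3c2)c1`: 32%
- compound 3 `CS(=O)(=O)Nc1cccc(-c2ccc3c(O)cccc3c2)c1`: 22%

In an assay for binding affinity to 17-beta-hydroxysteroid dehydrogenase type 2 (Homo sapiens), with a stated time of 20 min, tested at 1 uM (on this read-out higher numbers stand for more inhibition at the one concentration tested (going by the name of the read-out) and lower numbers for less inhibition), compound 3 gives 22%, the second highest of the three numbers. Its nearest neighbour is compound 1, with a number 2 percentage points higher from compound 1 to compound 3 (within the scatter); its furthest is compound 2, with a number 10 percentage points lower from compound 2 to compound 3 (within the scatter). Among the compounds with values here, only one step among the measured compounds lies beyond the scatter, a number 12 percentage points higher from compound 1 to compound 2 (beyond the scatter).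

Compound 4 `O=C(Nc1cccc(-c2ccc3c(O)cccc3c2)c1)c1ccccc1` differs from compound 3 in one place: benzoyl in place of methylsulfonyl on a nitrogen on an aromatic ring. Within the data shown here, no measured step exchanges one group for another on this nitrogen, so the only bearing steps are those at the same ring carbon, a number 2 percentage points higher from compound 1 to compound 3 (within the scatter) and a number 10 percentage points lower from compound 2 to compound 3 (within the scatter), both within the scatter. On that basis the exchange on the nitrogen is expected to give no step beyond the scatter, a number 2 percentage points higher from compound 3 to compound 4 (within the scatter). Compound 4 is therefore estimated at 24%, between 8% and 42% in this assay.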

Compound 4, a percentage reported as inhibition, at one concentration (the size of the read-out at that concentration, not a potency): < 10%
Compound 4: no number, only a limit (the forecaster's own chance of this, stated with the estimate: 2%); at least 14 percentage points between middle value and limit.
By their numbers in this assay, from the lowest: compounds 1, 3 and 2 (each within the scatter of the next, the first and the last beyond it). At a limit, below all of these: compound 4.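

In this assay compound 4 gives < 10%, which is a limit of the assay and not a number. The earlier compounds shown here showed only that methanesulfonamido in place of hydrogen gives a number 2 percentage points higher from compound 1 to compound 3 (within the scatter); the group on this nitrogen now proves able to move the read-out, since benzoyl in place of methylsulfonyl gives a number at least 12 percentage points lower from compound 3 to compound 4 (beyond the scatter). The size of this step is bounded on one side only, and it rests on a limit: the limit of < 10% in this assay, at which 1 of the 4 values shown sits.

The compounds shown do not separate the carbonyl of benzoyl from its aromatic ring as the part that goes with the lower read-out. They also leave open how acetyl or phenylsulfonyl on this nitrogen, or a free amine in its place, would read in this assay.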